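Dropping the Trifluoromethyl Group: What to Expect

The source may report more compounds than this note shows. Statements on the series, on what has been measured and on what is new or still open speak of the compounds shown alone.

Compound 1 `CN1CCN(c2nc(-c3ccc(Cl)c(Cl)c3)nc3[nH]cnc23)CC1` — in an assay on cells for displacement of a labelled ligand from adenosine receptor A1 (Homo sapiens), read by scintillation counting and radioligand binding, with a stated time of 60 min, tested at 10 uM (on this read-out higher numbers stand for more inhibition at the one concentration tested (going by the name of the read-out) and lower numbers for less inhibition), compound 1 gives > 80%, a limit of the assay rather than a number.
Compound 2 `CN1CCN(c2nc(-c3ccc(Cl)c(C(F)(F)F)c3)nc3[nH]cnc23)CC1` — in this assay compound 2 gives 52.4%.

The two measured compounds share one core and differ only in one group on the aromatic ring. Among the measured compounds shown here, the single measured step, a number at least 27.6 percentage points lower from compound 1 to compound 2 (beyond the scatter), shows that putting a trifluoromethyl group in place of a chloro group on that ring cost a substantial part of the inhibition. Compound 2 thus stands at the only outright number shown; the other value is a limit (the limit of > 80% in this assay, at which 1 of the 2 values shown sits).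

Compound 3 `CN1CCN(c2nc(-c3ccc(Cl)cc3)nc3[nH]cnc23)CC1` differs from compound 2 by hydrogen in place of trifluoromethyl on an aromatic carbon. For the measured compounds named here, no measured step removes a trifluoromethyl group outright, so the only guide is a number at least 27.6 percentage points lower from compound 1 to compound 2 (beyond the scatter), which shows that the trifluoromethyl group is linked to a lower read-out than a chloro group at that place. Removing it is therefore expected to raise the number, though the size is uncertain. Compound 3 is expected to give roughly 65%, between 35% and 90%, meaning an expected step of a number 12.6 percentage points higher from compound 2 to compound 3 (beyond the scatter).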

Compound 3, a percentage reported as inhibition, at one concentration (the size of the read-out at that concentration, not a potency): > 80%
Compound 3 gave a limit, no number; the forecaster's own chance of this, stated with the estimate: 25%; middle value at least 15 percentage points away from the limit.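

Removing the trifluoromethyl group from this aromatic carbon, the place ortho to a chloro group, gives a number at least 27.6 percentage points higher from compound 2 to compound 3 (beyond the scatter). The earlier loss in this assay could have reflected either the arrival of trifluoromethyl or the departure of chloro, but this step ties it to the trifluoromethyl group, since a bare hydrogen at the same place does not bring the same loss. For compound 3, the reading of > 80% is a limit of the assay and not a number, so hydrogen and chloro cannot be ranked against each other, and the step between compound 1 and compound 3 cannot be read because both sit at the limit: the limit of > 80% in this assay, at which 2 of the 3 values shown sit.

On these data alone, it remains open whether a methyl group, a fluoro group or a methoxy group at this place would keep the reading at the limit or lower it as trifluoromethyl does. As far as these compounds go, it is also open how compound 1 and compound 3 truly compare, as a reading at one concentration is not a potency and would need testing at lower concentrations to separate them.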